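Fluoro in place of chloro on compound 3

A few compounds are considered here, and "the series" means these few. Any claim that something is new, unique, unknown or untested is made for them only; others in the source may bear on it.

Of the compounds shown here, three have been measured in a functional assay on A549 cells (Homo sapiens) for antiproliferative activity, read by MTT assay, with a stated time of 72 h; on this read-out higher numbers stand for weaker inhibition and lower numbers for stronger inhibition. Compound 1 `Nc1nc(N)c2cc(CSC(=S)N3CCN(c4ccc(O)cc4)CC3)ccc2n1` gives 4210 nM, compound 2 `Cc1ccc(N2CCN(C(=S)SCc3ccc4nc(N)nc(N)c4c3)CC2)c(C)c1` gives 3000 nM and compound 3 `Nc1nc(N)c2cc(CSC(=S)N3CCN(c4ccccc4Cl)CC3)ccc2n1` gives 3610 nM. Compound 3 therefore lies within the scatter of both other compounds.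

Compound 4 `Nc1nc(N)c2cc(CSC(=S)N3CCN(c4ccccc4F)CC3)ccc2n1` differs from compound 3 by one substituent: fluoro in place of chloro on an aromatic carbon. This places fluoro in place of chloro on an aromatic carbon, ortho to a large group.

Among the compounds with values here, no measured compound carries fluoro, so the available steps bear on this change only indirectly. They are a 1.2-fold lower number from compound 1 to compound 3 (0.07 log units; within the scatter), a 1.2-fold higher number from compound 2 to compound 3 (0.08 log units; within the scatter) and a 1.4-fold lower number from compound 1 to compound 2 (0.15 log units; within the scatter), and each exchanges the whole aryl group on an amine nitrogen in a ring. All three stay within the scatter. No step beyond the scatter is therefore expected in this assay, and the data favour no direction. The expected change is a 1.0-fold lower number from compound 3 to compound 4 (0.01 log units; within the scatter). Compound 4 is estimated at 3500 nM, with an expected range of 1900 nM to 6500 nM.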

Compound 4, half-maximal inhibitory concentration: 6460 nM
Compound 4: the middle estimate sits 1.8-fold (0.27 log units) below what was measured; the range from low to high includes it.
By their numbers in this assay, from the lowest: compounds 2, 3, 1 and 4 (each within the scatter of the next, the first and the last beyond it).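

In this assay fluoro in place of chloro on an aromatic carbon, ortho to a large group, gives a 1.8-fold higher number from compound 3 to compound 4 (0.25 log units; within the scatter) and so stays inside the scatter for this exchange, as does the whole-aryl exchange in a 1.5-fold higher number from compound 1 to compound 4 (0.19 log units; within the scatter) on the same amine nitrogen. Within the data shown here, the 2-fluorophenyl group nevertheless yields the first step beyond the scatter, a 2.2-fold higher number from compound 2 to compound 4 (0.33 log units; beyond the scatter) and modest in size, which separates only this pair of the four compounds. Nothing at hand offers an explanation for that separation.

Whether a methoxy, an amine or a nitrile on this aromatic carbon would remain within the scatter of compound 3 is open. Also open, going by these compounds, is whether fluoro in place of chloro would read the same on a ring carrying a second substituent, such as the methyl of the 2,4-dimethylphenyl group.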